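Working notes: ethylamino to dimethylamino on the side chain

The source may report more compounds than this note shows. Statements on the series, on what has been measured and on what is new or still open speak of the compounds shown alone.

Measured so far in a functional assay on HeLa cells (Homo sapiens) for antiproliferative activity, read by MTT assay, with a stated time of 48 h (on this read-out lower numbers stand for stronger inhibition and higher numbers for weaker inhibition), as follows
compound 1 `C=C(c1cc(OC)c(OC)c(OC)c1)c1ccc(OC)cc1NC(=O)CO` gives 30 nM
compound 2 `C=C(c1cc(OC)c(OC)c(OC)c1)c1ccc(OC)cc1NC(=O)CN` gives 70 nM
compound 3 `C=C(c1cc(OC)c(OC)c(OC)c1)c1ccc(OC)cc1NC(=O)CNCC` gives 430 nM

Compound 3 at 430 nM has the highest number of the three and is the weakest inhibitor here, beyond the scatter from both others. Compound 4 `C=C(c1cc(OC)c(OC)c(OC)c1)c1ccc(OC)cc1NC(=O)CN(C)C` keeps the shared core and carries dimethylamino in place of ethylamino on a saturated chain carbon bound to a carbonyl carbon. The count reads dimethylamino in place of ethylamino on a saturated chain carbon bound to a carbonyl carbon and the two structures have the same atoms, joined differently.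

The closest measured change is a 6.1-fold higher number from compound 2 to compound 3 (0.79 log units; beyond the scatter) for ethyl in place of hydrogen on an amine nitrogen, a modest step. Two further steps replace hydroxy on the same chain carbon: a 2.3-fold higher number from compound 1 to compound 2 (0.37 log units; beyond the scatter) is modest and a 14-fold higher number from compound 1 to compound 3 (1.16 log units; beyond the scatter) is large. Within the data shown here, no measured compound carries dimethylamino, so these steps give only a loose guide. A small move toward a lower number in this assay is expected, probably within the scatter, although a modest step in either direction remains possible. The expected change is a 1.7-fold lower number from compound 3 to compound 4 (0.24 log units; within the scatter) on this estimate. In this assay the estimate for compound 4 is 250 nM with 80 nM to 700 nM as the expected range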

Compound 4, half-maximal inhibitory concentration: 370 nM
Estimate against measurement, compound 4: 1.5-fold (0.17 log units) below; low and high end bracket the measured number.
By their numbers in this assay, from the lowest: compound 1; then compound 2; then compounds 4 and 3 (each within the scatter of the next).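

In this assay, exchanging ethylamino for dimethylamino on the saturated chain carbon bound to the carbonyl carbon gives a 1.2-fold lower number from compound 3 to compound 4 (0.07 log units; within the scatter), so the two groups cannot be told apart here, even though ethylamino counts 1 hydrogen-bond donor and dimethylamino counts 0. Dimethylamino stays well separated from the smaller groups at this place, with a 5.3-fold higher number from compound 2 to compound 4 (0.72 log units; beyond the scatter) and a 12-fold higher number from compound 1 to compound 4 (1.09 log units; beyond the scatter), so the separation first seen with ethylamino is not unique to that group and also appears with a second amine of the same heavy-atom count. Nothing available bears on why the numbers fall this way.

Still open, going by these compounds, is whether the numbers keep this level with larger groups at the same chain carbon, such as diethylamino, pyrrolidine or morpholine, or whether they move further from those of compound 1 and compound 2. Also open, on these data alone, is how a carboxylic acid or methoxy group at this place would compare with the hydroxy of compound 1, and whether a longer chain between the carbonyl carbon and the amine would change the picture for amino, ethylamino and dimethylamino alike.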